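The compounds below may be only part of what the source reports. "The series", "measured", "known", "first", "only" and "open" are said of these compounds alone.

Measured in a functional assay on HL-60 cells (Homo sapiens) for cytotoxicity, read by MTT assay, with a stated time of 3 days; a lower number here means a stronger inhibitor, a higher number a weaker inhibitor:
compound 1 `N#Cc1c(NN)nc(SCc2nc3ccccc3[nH]2)nc1-c1ccccc1`: 11.9 nM
compound 2 `CCNc1nc(SCc2nc3ccccc3[nH]2)nc(-c2ccccc2)c1C#N`: 3.96 nM
compound 3 `N#Cc1c(Nc2nccs2)nc(SCc2nc3ccccc3[nH]2)nc1-c1ccccc1`: 11.9 nM

Compound 3 stands level with compound 1 and, together with it, at the top of the three numbers, with only compound 2 lower. Compound 4 `N#Cc1c(NC(N)=O)nc(SCc2nc3ccccc3[nH]2)nc1-c1ccccc1` has not been measured. The change from compound 3 is carbamoyl in place of 1,3-thiazol-2-yl on a nitrogen on an aromatic ring, which, cut one bond further out, reads (1,3-thiazol-2-yl)amino to ureido.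

Within the data shown here, three measured steps bear on this change, all of them exchanges on the same nitrogen. They are a 3.0-fold lower number from compound 1 to compound 2 (0.48 log units; beyond the scatter), no change at the digits printed from compound 1 to compound 3 (within the scatter) and a 3.0-fold higher number from compound 2 to compound 3 (0.48 log units; beyond the scatter). Among the measured compounds shown here, the largest of these is modest, and the only exchange that leaves the 1,3-thiazol-2-yl group gives either no change or a modest fall. For the measured compounds named here, no measured compound carries the carbamoyl group, so this evidence is indirect. In this assay, no shift beyond the scatter is expected, although a modest move in either direction remains possible. The expected step is a 1.2-fold lower number from compound 3 to compound 4 (0.08 log units; within the scatter), a small one. For compound 4 the estimated value is 10 nM, with an expected range of 4 nM to 28 nM.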

Compound 4, half-maximal inhibitory concentration: 2.9 nM
Beside the measured number, compound 4's estimate is 3.4-fold (0.54 log units) above it; the measured number lies below the stated range.
By their numbers in this assay, from the lowest: compounds 4 and 2 (each within the scatter of the next); then compounds 1 and 3 (each within the scatter of the next).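

In this assay, among these compounds, carbamoyl on this nitrogen separates from two of the earlier groups (a 4.1-fold lower number from compound 3 to compound 4 (0.61 log units; beyond the scatter)) and (a 4.1-fold lower number from compound 1 to compound 4 (0.61 log units; beyond the scatter)), so ethyl is no longer the only group at this position that stands apart from amino and 1,3-thiazol-2-yl. Against ethyl, carbamoyl shows no difference beyond the scatter (a 1.4-fold lower number from compound 2 to compound 4 (0.14 log units; within the scatter)), and the four compounds fall into two pairs, compounds 2 and 4 on one side and compounds 1 and 3 on the other; having no ring on this nitrogen does not sort them, as amino in compound 1 goes against that reading by sitting level with the 1,3-thiazol-2-yl of compound 3. Nothing in the data offers a reason for this split into pairs.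

The compounds shown do not tell whether the carbonyl or the terminal amine of the ureido group matters more, a question that acetyl or a methyl-capped urea on the same nitrogen would address. Nor do they show whether a longer chain such as butyl would stay with ethyl and carbamoyl, or whether the same order holds on any cell line other than this one.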